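The compounds below may be only part of what the source reports. "The series", "measured", "known", "first", "only" and "open" are said of these compounds alone.

Measured so far:
- compound 2 `CCCCCCCCCCCCCCCCCCOCC1CC(COCCCCCCC[n+]2ccsc2)CO1` — 2.1 mg/kg
- compound 1 `CCCCCCCCCCCCCCCCOCC1OCC(COCCCC[n+]2ccsc2)O1` — 2.7 mg/kg

In a functional assay on artery with platelet-activating factor receptor (Rattus norvegicus) as the target (a higher number here means that more compound is needed for the effect, a lower number that less compound is needed), compound 2 holds the lowest of the two numbers, but compound 1 sits within the scatter of it, so the two are not separated. Compound 3 `CCCCCCCCCCCCCCCCCCOCC1CC(COC(=O)CCCCC[n+]2ccsc2)CO1` is the next member; it differs from compound 2 by a group of 12 heavy atoms (9 carbon, 1 nitrogen, 1 oxygen, 1 sulfur; one five-membered aromatic ring with 2 hetero atoms) in place of a group of 12 heavy atoms (10 carbon, 1 nitrogen, 1 sulfur; one five-membered aromatic ring with 2 hetero atoms), on an oxygen on a saturated carbon. No measured pair in the series carries this kind of exchange, so nothing shown fixes its size. The expectation is a step of a 1.4-fold higher number from compound 2 to compound 3 (0.15 log units; within the scatter), that is no shift beyond the scatter, leaning if anything towards a slightly higher dose. Compound 3 is estimated at 3 mg/kg, within 1.2 mg/kg to 7.5 mg/kg.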

Compound 3, dose for 50% inhibition: 1.1 mg/kg
Estimate against measurement, compound 3: 2.7-fold (0.44 log units) above; the whole stated range lies above it.
By their numbers in this assay, from the lowest: compounds 3, 2 and 1 (each within the scatter of the next, the first and the last beyond it).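

In this assay, exchanging the all-carbon-linked group on an oxygen on a saturated carbon for the group with a double bond outside aromatic rings gives a 1.9-fold lower number from compound 2 to compound 3 (0.28 log units; within the scatter). The added hydrogen-bond acceptor and the double bond are therefore accepted at this position, with no separation of compound 3 from compound 2. No measurement shown gives a reason for this step.

Still open, as far as these compounds go, is whether an amide or a longer chain carrying the five-membered aromatic ring on this oxygen would shift the number beyond the scatter.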